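The compounds below may be only part of what the source reports. "The series", "measured", "known", "first", "only" and "open" are said of these compounds alone.

Three compounds share one core. Compound 1 `O=C(Cc1cccnc1)c1cc2cc(F)ccc2[nH]1` gives 24% in an in vitro assay on P815B cells for inhibition of Indoleamine 2,3-dioxygenase 1 (Mus musculus), tested at 20 uM; on this read-out lower numbers stand for less inhibition and higher numbers for more inhibition at the one concentration tested (going by the name of the read-out). Compound 2 `O=C(Cc1cccnc1)c1cc2cc([N+](=O)[O-])ccc2[nH]1` is reported in this assay only as "not active" (no number reported), with no number attached. Within the data shown here, compound 3 `O=C(Cc1cccnc1)c1cc2cc(Cl)ccc2[nH]1` gives 24% in this assay, which places it level with compound 1; the one measured change, no change at the digits printed from compound 1 to compound 3 (within the scatter), stayed within the scatter. Compound 4 `O=C(Cc1cccnc1)c1cc2cc(OC(F)(F)F)ccc2[nH]1` differs from compound 3 in a single place: trifluoromethoxy in place of chloro on an aromatic carbon. Among the measured compounds shown here, that measured step is the only guide here, and it swapped one group for another at the same place without moving the read-out, so for compound 4 a step of about a number 4 percentage points lower from compound 3 to compound 4 (within the scatter) is expected, nothing beyond the scatter. Compound 4 is therefore estimated at 20% in this assay, between 5% and 38%.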

Compound 4, a percentage reported as inhibition, at one concentration (the size of the read-out at that concentration, not a potency): 12%
Compound 4: the middle estimate sits 8 percentage points above what was measured; measured number inside the range.
By their numbers in this assay, from the lowest: compound 4; then compounds 1 and 3 (each within the scatter of the next).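

In this assay, trifluoromethoxy brought a number 12 percentage points lower from compound 3 to compound 4 (beyond the scatter) and a number 12 percentage points lower from compound 1 to compound 4 (beyond the scatter) at this position. Unlike the swap of fluoro for chloro, this change does move the read-out, so the position is not indifferent to the group it carries, although a single compound shows this only for one group.

On these data alone, whether an amine, a carboxylic acid or a longer chain here would raise or lower the read-out stays open, and steps involving compound 2 cannot be read. Nothing shown explains the drop.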